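The source may report more compounds than this note shows. Statements on the series, on what has been measured and on what is new or still open speak of the compounds shown alone.

In a functional assay on SW480 cells (Homo sapiens) for antiproliferative activity, read by sulforhodamine B assay, with a stated time of 48 h (on this read-out lower numbers stand for stronger inhibition and higher numbers for weaker inhibition), compound 1 (`COc1ccc(/C=C/C(=O)c2ccccc2-c2ccc(OC)c(OC)c2)cc1OC`) gives 7600 nM and compound 2 (`COc1ccc(OC)c(/C=C/C(=O)c2ccccc2-c2ccc(OC)c(OC)c2)c1`) gives 5200 nM on the same read-out. These two numbers are all that has been measured so far, and they lie within the scatter of each other, so compound 1 has no measured neighbour clearly apart from it. Compound 3 (`COc1ccc(/C=C/C(=O)c2ccccc2-c2ccc(F)nc2)cc1OC`) differs from compound 1 by 6-fluoropyridin-3-yl in place of 3,4-dimethoxyphenyl on an aromatic carbon, ortho to a large group (6-fluoropyridin-3-yl in place of 3,4-dimethoxyphenyl on an aromatic carbon). Among the compounds with values here, the only measured step (a 1.5-fold lower number from compound 1 to compound 2 (0.16 log units; within the scatter)) concerns the dimethoxyphenyl on the double-bonded chain carbon and not this aromatic carbon, so it bears on the exchange only indirectly. Within the data shown here, no measurement yet covers a change at this place. On these data alone, no step beyond the scatter is therefore expected in this assay, and the direction stays open, with a wide margin on either side. The estimated step (a 1.1-fold lower number from compound 1 to compound 3 (0.04 log units; within the scatter)) is accordingly small and uncertain. For compound 3 the expected value is 7000 nM within an estimated range from 2500 nM to 20000 nM in this assay.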

Compound 3, half-maximal inhibitory concentration: 1300 nM
Compound 3: middle estimate off by 5.4-fold (0.73 log units), on the high side; measured number below the stated range.
By their numbers in this assay, from the lowest: compound 3; then compounds 2 and 1 (each within the scatter of the next).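

The aromatic carbon ortho to a large group, which the earlier pair left unchanged, proves responsive in this assay: putting 6-fluoropyridin-3-yl in place of 3,4-dimethoxyphenyl gives a 5.8-fold lower number from compound 1 to compound 3 (0.77 log units; beyond the scatter), the only step among these compounds that lies beyond the scatter. The exchange alters several things at once, replacing a ring of carbon only with a ring with 1 hetero atom and going from 10 heavy atoms to 7, and this single step cannot separate these changes. Nothing available explains why the number falls.

A plain pyridin-3-yl or a 4-fluorophenyl at this aromatic carbon would show whether the ring nitrogen, the fluorine or only their combination goes with the lower number, while a 6-aminopyridin-3-yl would test whether the fluorine can be exchanged at all. On these data alone, it also remains open whether the same exchange would bring a similar step on the core of compound 2, which carries 2,5-dimethoxyphenyl on the double-bonded chain carbon.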